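Removing the Dihydroxypropyl Chain From Compound 2

The source may report more compounds than this note shows. Statements on the series, on what has been measured and on what is new or still open speak of the compounds shown alone.

Compound 1, `CCCc1nc(C)c2c(C)nn(CC(O)CO)c(=O)n12`: in a functional assay for inhibition, with Homo sapiens as the target (a lower number here means a stronger inhibitor, a higher number a weaker inhibitor), compound 1 gives > 48000 nM, which is a limit of the assay.
Compound 2, `CCCc1nc(C)c2cnn(CC(O)CO)c(=O)n12`: in this assay compound 2 gives > 48000 nM, again a limit.
Compound 3, `CCc1nnc(O)n2c(C)nc(C)c12`: in this assay compound 3 gives > 48000 nM, also a limit.

Compound 2 therefore stands at the limit of this assay, and it is not alone there: the limit of > 48000 nM in this assay, at which 3 of the 3 values shown sit. Within the data shown here, the one step that can be built from these compounds, a step that the two limits leave unreadable from compound 1 to compound 2, cannot be sized, since both of its ends are limits.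

Compound 4, `CCCc1nc(C)c2cnn(C)c(=O)n12`, differs from compound 2 by hydrogen in place of 1,2-dihydroxyethyl on a saturated chain carbon bound to an aromatic nitrogen. Among the measured compounds shown here, no measured step touches this part of the structure, so nothing here shows how the assay answers to the change. What the data do show is that every measured compound sits at the limit, whatever else is varied.

On that basis compound 4 is expected to sit at the limit too, with an estimate of 60000 nM and a range from 20000 nM to 200000 nM. The expected step that the limit leaves unreadable from compound 2 to compound 4 is no more than scatter.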

Compound 4, half-maximal inhibitory concentration: 20000 nM
Beside the measured number, compound 4's estimate is 3.0-fold (0.48 log units) above it, within the range that was stated.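

Among these compounds, compound 4 is the first compound here to give a readable number in this assay, and the other compounds all remain at a limit: the limit of > 48000 nM in this assay, at which 3 of the 4 values shown sit. Among the compounds shown here, the change from 2,3-dihydroxypropyl to methyl gives an at least 2.4-fold lower number from compound 2 to compound 4 (0.38 log units; beyond the scatter), so this position responds to what is placed on it, which the earlier compounds could not show. From the compounds shown here alone, compound 2 has only a limit, so this step is a minimum and its full size remains unknown.

Only 2,3-dihydroxypropyl and methyl are shown at this position, so it remains open whether the lower number goes with the loss of the hydroxyl groups or with the shorter chain. An ethyl, a propyl or a 2-hydroxyethyl group here could help separate the two, and a benzyl group would test a much larger substituent.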